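Compound 4: a substituent swap near the limit

The source may hold more compounds than are shown below. What is called first, only, known or untested is meant among the compounds shown, and "the series" means these compounds.

Measured in an ADME assay on THP-1 cells (Homo sapiens) for cytotoxicity, read by MTT assay, with a stated time of 72 h; a lower number here means that less compound is needed, a higher number that more compound is needed for the effect:
Compound 1 `O=c1nc(-c2ccccc2)c2cc(-c3ccccc3)ccc2[nH]1`: > 50000 nM, a limit
Compound 2 `O=c1nc(-c2ccccc2)c2cc(-c3ccccc3F)ccc2[nH]1`: 50000 nM
Compound 3 `Cn1cc(-c2ccc3[nH]c(=O)nc(-c4ccccc4)c3c2)cn1`: > 50000 nM, a limit

In this assay compound 3 stands at > 50000 nM, which is a limit and not a number. Compound 4 `CN1CCN(c2ccc3[nH]c(=O)nc(-c4ccccc4)c3c2)CC1` differs from it on one aromatic carbon: 4-methylpiperazin-1-yl in place of 1-methyl-1H-pyrazol-4-yl on an aromatic carbon. Two measured steps change the group on that carbon, a step that the two limits leave unreadable from compound 1 to compound 3 and a number no lower from compound 2 to compound 3 (the limit leaves the size open). Neither has a readable size because of the limit of > 50000 nM in this assay, at which 2 of the 3 values shown sit. With compound 2 at 50000 nM, no change beyond the scatter is expected, in either direction. The expected step is an at least 1.2-fold lower number from compound 3 to compound 4 (0.09 log units; that floor lies within the scatter). Compound 4 is estimated at 40000 nM, with an expected range of 12000 nM to 60000 nM.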

Compound 4, half-maximal effective concentration: > 50000 nM
Compound 4: no number, only a limit (the forecaster's own chance of this, stated with the estimate: 55%); at least 1.2-fold (0.09 log units) between middle value and limit.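

In this assay compound 4 gives > 50000 nM, which is a limit and not a number. So 4-methylpiperazin-1-yl, a six-membered non-aromatic ring, joins the aromatic groups on this aromatic carbon, with a number no lower from compound 2 to compound 4 (the limit leaves the size open) as the only new step that shows a direction. The sizes of the three new steps to compound 4 cannot be read, because the values stop at one edge: the limit of > 50000 nM in this assay, at which 3 of the 4 values shown sit.

From the compounds shown here alone, how compound 1, compound 3 and compound 4 rank among themselves stays open. Also open, going by these compounds, is whether a carboxylic acid or a primary amine on this carbon would give a readable number.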